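The source may report more compounds than this note shows. Statements on the series, on what has been measured and on what is new or still open speak of the compounds shown alone.

Measured so far in a functional assay on A549 cells (Homo sapiens) for antiproliferative activity, read by MTT assay, with a stated time of 72 h; on this read-out higher numbers stand for weaker inhibition and lower numbers for stronger inhibition:

- compound 1 `CC/C=C/C(=O)Nc1cccc(Oc2nc(Nc3ccn(C)n3)nc3c2CSCC3)c1` gives 36800 nM
- compound 2 `CCC/C=C/C(=O)Nc1cccc(Oc2nc(Nc3ccn(C)n3)nc3c2CSCC3)c1` gives 8190 nM
- compound 3 `CC(C)=CC(=O)Nc1cccc(Oc2nc(Nc3ccn(C)n3)nc3c2CSCC3)c1` gives 44200 nM

Compound 2 has the lowest number of the three. It stands apart from the other two, with a 4.5-fold lower number from compound 1 to compound 2 (0.65 log units; beyond the scatter) on one side and a 5.4-fold higher number from compound 2 to compound 3 (0.73 log units; beyond the scatter) on the other.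

Compound 4 `CCC/C=C/C(=O)Nc1cccc(Oc2nc(Nc3ccc(OC)nc3)nc3c2CSCC3)c1` keeps the pent-1-en-1-yl on the carbonyl carbon of compound 2. The change lies elsewhere: 6-methoxypyridin-3-yl in place of 1-methyl-1H-pyrazol-3-yl on a nitrogen on an aromatic ring. In words, 6-methoxypyridin-3-yl stands in place of 1-methyl-1H-pyrazol-3-yl on a nitrogen on an aromatic ring.

Going by the values given here, none of the measured steps touches this place. All of them concern the group on the carbonyl carbon, and the largest, a 5.4-fold higher number from compound 2 to compound 3 (0.73 log units; beyond the scatter), is modest. The data therefore give no direction for the new change, and its size can only be borrowed loosely from those steps. In this assay the expected outcome is a 1.0-fold lower number from compound 2 to compound 4 (0.01 log units; within the scatter), with a wide margin on either side. For compound 4 the estimated value is 8000 nM, with an expected range from 2000 nM to 32000 nM.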

Compound 4, half-maximal inhibitory concentration: 10800 nM
Compound 4: middle estimate off by 1.4-fold (0.13 log units), on the low side; measured number inside the range.
By their numbers in this assay, from the lowest: compounds 2 and 4 (each within the scatter of the next); then compounds 1 and 3 (each within the scatter of the next).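

In this assay, going by these compounds alone, the amino nitrogen on the aromatic ring, a place that none of the earlier steps touched, shows no change beyond the scatter when 6-methoxypyridin-3-yl stands in place of 1-methyl-1H-pyrazol-3-yl, with a 1.3-fold higher number from compound 2 to compound 4 (0.12 log units; within the scatter). With pent-1-en-1-yl kept on the carbonyl carbon, this one pair shows that a six-membered aromatic ring with 1 hetero atom can replace a five-membered aromatic ring with 2 hetero atoms without a clear shift in the number. No measured evidence on this pair bears on why the two groups give such similar numbers.

On these data alone, it remains open whether the exchange would behave the same way with but-1-en-1-yl or 2-methylprop-1-en-1-yl on the carbonyl carbon. The compounds shown also leave open how a phenyl group carrying a dimethylamino substituent or a carboxylic acid would fare on that nitrogen.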